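A Third Methoxy Group Enters Compound 1

A few compounds are considered here, and "the series" means these few. Any claim that something is new, unique, unknown or untested is made for them only; others in the source may bear on it.

Compound 1 `COc1ccc(C(=O)/C=C/c2cc(-c3cc(OC)c(OC)c(OC)c3)n[nH]2)cc1OC` was tested in a functional assay on OVCAR-4 cells (Homo sapiens) for cytotoxicity, read by sulforhodamine B assay, with a stated time of 48 h, tested at 1 uM (a higher number here means a weaker effect of the compound at the concentration tested, a lower number a stronger effect), where compound 1 gives 70%. Compound 3 `COc1cc(-c2cc(/C=C/C(=O)c3ccc(F)c(F)c3)[nH]n2)cc(OC)c1OC` gives 67%, and compound 2 `COc1ccc(C(=O)/C=C/c2cc(-c3cc(OC)c(OC)c(OC)c3)n[nH]2)cc1` gives 80%; all three numbers lie within the usual scatter of one another. Compound 4 `COc1cc(C(=O)/C=C/c2cc(-c3cc(OC)c(OC)c(OC)c3)n[nH]2)cc(OC)c1OC` differs from compound 1 by methoxy in place of hydrogen on an aromatic carbon. The step bearing most directly on this is the opposite change, a number 10 percentage points higher from compound 1 to compound 2 (within the scatter), which stayed within the scatter. The steps of a number 3 percentage points lower from compound 1 to compound 3 (within the scatter) and a number 13 percentage points lower from compound 2 to compound 3 (beyond the scatter) alter a different group and speak less to it. Since removing one methoxy moved the number only within the scatter, the expected step of a number 5 percentage points lower from compound 1 to compound 4 (within the scatter) is small. Compound 4 is therefore estimated at 65%, with a range from 50% to 80%.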

Compound 4, a percentage reported as activity, at one concentration (the size of the read-out at that concentration, not a potency): 79%
The estimate for compound 4 lay 14 percentage points below the measured number, and the stated range covers the measured number.
By their numbers in this assay, from the lowest: compounds 3, 1, 4 and 2 (each within the scatter of the next, the first and the last beyond it).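

Adding a third methoxy to this ring gives a number 9 percentage points higher from compound 1 to compound 4 (within the scatter) in this assay. Set beside the removal of a methoxy, a number 10 percentage points higher from compound 1 to compound 2 (within the scatter), it shows that neither one methoxy more nor one fewer than in compound 1 moves the number beyond the scatter, so this assay does not separate these three methoxy patterns. Nothing available explains this result.

As far as these compounds go, whether a different group on this ring, such as an amine, a carboxylic acid or a longer alkoxy chain, would move the number beyond the scatter remains open.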